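Removing a Methyl from a Fused Bicyclic Phenol Core

The source may hold more compounds than are shown below. What is called first, only, known or untested is meant among the compounds shown, and "the series" means these compounds.

Measured compounds:
compound 1 `Cc1cc(C)c2c(O)cc(-c3ccc(Cl)cc3)nc2n1` with 19500 nM
compound 2 `Cc1ccnc2nc(-c3ccc(Cl)cc3)cc(O)c12` with 5130 nM
compound 3 `COc1cccc(-c2cc(O)c3c(C)ccnc3n2)c1` with 58.9 nM

In a functional assay on cells (Tumor Cell line, Homo sapiens) for cytotoxicity (a higher number here means a weaker inhibitor of growth, a lower number a stronger inhibitor of growth), compound 1 gives 19500 nM, while compound 2 gives 5130 nM and compound 3 gives 58.9 nM. Compound 1 and compound 2 differ by hydrogen in place of methyl on an aromatic carbon and the step is a 3.8-fold lower number from compound 1 to compound 2 (0.58 log units; beyond the scatter). The difference between the cores of compound 1 and compound 3 is not broken down here. Compound 4 `COc1cccc(-c2cc(O)c3cccnc3n2)c1` differs from compound 3 by hydrogen in place of methyl on an aromatic carbon. This is the same kind of change as that from compound 1 to compound 2, not the same change: there the methyl left a carbon next to the ring nitrogen, meta to a methyl group and para to a fused ring, whereas here it leaves a carbon ortho to a fused ring, meta to a fused ring and opposite the ring nitrogen. In this assay the step is expected to be a 1.3-fold lower number from compound 3 to compound 4 (0.12 log units; within the scatter), resting on the measured step of a 3.8-fold lower number from compound 1 to compound 2 (0.58 log units; beyond the scatter). The place of the change is not the same, and the expectation is tempered with that in mind. Compound 4 is therefore estimated at 45 nM, expected between 15 nM and 150 nM.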

Compound 4, concentration for 50% growth inhibition: 135 nM
Beside the measured number, compound 4's estimate is 3.0-fold (0.48 log units) below it, within the range that was stated.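

In this assay, hydrogen in place of methyl on an aromatic carbon gave a 2.3-fold higher number from compound 3 to compound 4 (0.36 log units; beyond the scatter) and did not carry over from the earlier core in direction or in size: the same change on two cores in this assay, a 3.8-fold lower number (0.58 log units; beyond the scatter) from compound 1 to compound 2 and a 2.3-fold higher number (0.36 log units; beyond the scatter) from compound 3 to compound 4, 8.7-fold (0.94 log units) apart, beyond the scatter of two such steps.
So, across these two pairs, the result of this change on one core did not predict its result on the other. This does not show what separates the pairs, as they differ both in the place the methyl leaves and in the rest of the molecule, and two pairs set no rule for the series.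

The compounds shown leave open how a larger or different group on this aromatic carbon, such as an ethyl chain or an amine, would compare with methyl and hydrogen. They also leave open whether either step would hold with the other aromatic substituent in place.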